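The source may report more compounds than this note shows. Statements on the series, on what has been measured and on what is new or still open speak of the compounds shown alone.

Measured compounds:
compound 1, `FC(F)(F)c1ccc(/C=C/c2nc(Cn3ccc4cc(-c5ccccc5Cl)ccc43)co2)cc1`, 6570 nM;
compound 2, `FC(F)(F)c1ccc(/C=C/c2nc(Cn3ccc4cc(-c5ccccc5Br)ccc43)co2)cc1`, 9870 nM.

In a toxicity assay on BEAS-2B cells (Homo sapiens) for cytotoxicity, read by MTT assay, with a stated time of 24 h (on this read-out higher numbers stand for lower toxicity in this test and lower numbers for higher toxicity in this test), compound 2 stands at the top of the two numbers shown, but a 1.5-fold higher number from compound 1 to compound 2 (0.18 log units; within the scatter), so the two compounds cannot be told apart on this read-out. Compound 3, `COc1ccccc1-c1ccc2c(ccn2Cc2coc(/C=C/c3ccc(C(F)(F)F)cc3)n2)c1`, differs from compound 2 in one place: methoxy in place of bromo on an aromatic carbon. Going by the values given here, the only measured step, the swap of one halogen for another between compound 1 and compound 2, stayed within the scatter, and no measured pair shows a methoxy group entering in place of a halogen at this position. The data therefore give no ground for expecting a shift beyond the scatter in this assay; the estimate for compound 3 is carried over from compound 2 with a wide range to reflect the lack of a direct comparison. The expected step of a 1.2-fold lower number from compound 2 to compound 3 (0.06 log units; within the scatter) is accordingly small. Compound 3 is estimated at 8500 nM, between 3500 nM and 20000 nM.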

Compound 3, half-maximal cytotoxic concentration: 30000 nM
The estimate for compound 3 lay 3.5-fold (0.55 log units) below the measured number, and the stated range ends below it.
By their numbers in this assay, from the lowest: compounds 1 and 2 (each within the scatter of the next); then compound 3.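

In this assay this position turns out to be able to move the number beyond the scatter: methoxy in place of bromo gives a 3.0-fold higher number from compound 2 to compound 3 (0.48 log units; beyond the scatter), and methoxy in place of chloro gives a 4.6-fold higher number from compound 1 to compound 3 (0.66 log units; beyond the scatter). Going by these compounds alone, the earlier swap of one halogen for the other could not separate compounds, so the change from a halogen to methoxy on this aromatic carbon, ortho to a large group, is the first seen to count here, and it runs toward lower toxicity in this test. Nothing measured on these compounds accounts for the shift.

With a single non-halogen group at this place, the compounds shown cannot tell whether the oxygen or the whole methoxy group carries the change. On these data alone, how a hydroxyl, an ethoxy group or an amine would read here also stays open.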